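A Small Methyl Addition on Two Related Cores

A few compounds are considered here, and "the series" means these few. Any claim that something is new, unique, unknown or untested is made for them only; others in the source may bear on it.

Of the compounds shown here, three have been tested so far in a functional assay on A-375 cells (Homo sapiens) for cytotoxicity, read by MTT assay, with a stated time of 72 h, tested at 3 uM; a lower number here means less inhibition of growth, a higher number more inhibition of growth at the concentration tested. Compound 1 `N/C(=N\NC(=S)N1CCOCC1)c1ccccn1` gives 19.3% in this assay. Compound 2 `Cc1ccnc(/C(N)=N/NC(=S)N2CCOCC2)c1` gives 66.6% in this assay, and compound 3 `N/C(=N\NC(=S)N1CCCCC1)c1ccccn1` gives 86.5%. Compound 3 shows the highest of the three numbers, and its steps to both others lie beyond the scatter.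

The change from compound 1 to compound 2 is methyl in place of hydrogen on an aromatic carbon, and it made a step of a number 47.3 percentage points higher from compound 1 to compound 2 (beyond the scatter). The two cores differ by piperidin-1-yl in place of morpholin-4-yl on a thiocarbonyl carbon, a change that on its own made a step of a number 67.2 percentage points higher from compound 1 to compound 3 (beyond the scatter). Compound 4 `Cc1ccnc(/C(N)=N/NC(=S)N2CCCCC2)c1` has not yet been measured; it differs from compound 3 by methyl in place of hydrogen on an aromatic carbon, the same change as that from compound 1 to compound 2, since the place is described in the same words.

Compound 3 already stands high, so little room remains before complete inhibition. The step from compound 3 to compound 4 is therefore expected to be smaller than the earlier one, estimated at a number 3.5 percentage points higher from compound 3 to compound 4 (within the scatter), because compound 3 already gives 86.5%. Compound 4 is expected to reach about 90% in this assay, with a likely range from 78% to 99%.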

Compound 4, percent growth inhibition at one concentration: 69.5%
For compound 4 the middle estimate is 20.5 percentage points above the measured one, and the stated range ends above it.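

Methyl in place of hydrogen on an aromatic carbon gave a number 17 percentage points lower from compound 3 to compound 4 (beyond the scatter), so in this assay this change did not carry over from the core of compound 1 to the core of compound 3: the same change on two cores in this assay, a number 47.3 percentage points higher (beyond the scatter) from compound 1 to compound 2 and a number 17 percentage points lower (beyond the scatter) from compound 3 to compound 4, 64.3 percentage points apart, beyond the scatter of two such steps. Piperidin-1-yl in place of morpholin-4-yl on a thiocarbonyl carbon gave a number 2.9 percentage points higher from compound 2 to compound 4 (within the scatter), so this change did not carry over either, and its large step on the unmethylated core has no counterpart on the methylated core: the same change on two cores in this assay, a number 67.2 percentage points higher (beyond the scatter) from compound 1 to compound 3 and a number 2.9 percentage points higher (within the scatter) from compound 2 to compound 4, 64.3 percentage points apart, beyond the scatter of two such steps. These four compounds show that the effects of the two changes do not simply add up in this series, but they do not show why, nor how either change would behave on any further core.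

A chlorine atom or a methoxy group on the same aromatic carbon might follow the methyl or might not. It also remains open how a pyrrolidin-1-yl or a dimethylamino group on the thiocarbonyl carbon would compare with the two rings shown.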